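The source may hold more compounds than are shown below. What is called first, only, known or untested is meant among the compounds shown, and "the series" means these compounds.

Measured compounds:

compound 1 `COc1ccc2nc(Cl)c(/C=C\c3cc(C(F)(F)F)cc(C(F)(F)F)c3)cc2c1`: 4140 nM
compound 2 `FC(F)(F)c1cc(/C=C\c2cc3ccccc3nc2Cl)cc(C(F)(F)F)c1`: 6780 nM
compound 3 `FC(F)(F)c1ccc(/C=C\c2cc3ccccc3nc2Cl)c(C(F)(F)F)c1`: 35900 nM

All three were run in a functional assay on HeLa cells (Homo sapiens) for antiproliferative activity, read by sulforhodamine B assay, with a stated time of 72 h; a higher number here means a weaker inhibitor, a lower number a stronger inhibitor. Compound 3 gives the highest number of the three; its nearest neighbour is compound 2 and the furthest is compound 1, both gaps lying beyond the scatter. Compound 2 and compound 3 share the same atoms joined differently; the difference between the two cores is not broken down here.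

One change recurs. From compound 2 to compound 1 the change is methoxy in place of hydrogen on an aromatic carbon, and it gave a 1.6-fold lower number from compound 2 to compound 1 (0.21 log units; within the scatter). The unmeasured compound 4 `COc1ccc2nc(Cl)c(/C=C\c3ccc(C(F)(F)F)cc3C(F)(F)F)cc2c1` arises from compound 3 by methoxy in place of hydrogen on an aromatic carbon; the place is the same word for word, so this is the same change on a different core.

Because the step of a 1.6-fold lower number from compound 2 to compound 1 (0.21 log units; within the scatter) sat within the scatter, the expectation for compound 4 in this assay is a similarly small step, a 1.6-fold lower number from compound 3 to compound 4 (0.19 log units; within the scatter), with the proviso that a single prior example is thin ground and the core of compound 3 may answer differently. Compound 4 is therefore estimated at 23000 nM, with a plausible range from 10000 nM to 55000 nM.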

Compound 4, half-maximal inhibitory concentration: > 50000 nM
Compound 4 gave a limit, no number; the forecaster's own chance of this, stated with the estimate: 10%; middle value at least 2.1-fold (0.33 log units) away from the limit.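

In this assay, methoxy in place of hydrogen on an aromatic carbon gives an at least 1.3-fold higher number from compound 3 to compound 4 (0.14 log units; that floor lies within the scatter). Going by these compounds, compound 4 reads > 50000 nM, which is a limit of the assay and not a number, so the true size of this step remains unknown and only its floor can be read. The pair of steps neither shows that the change carries over from one core to the other nor shows that it fails to do so, and no rule for transferring it in this series can be drawn from them: the same change on two cores in this assay, a 1.6-fold lower number (0.21 log units; within the scatter) from compound 2 to compound 1 and an at least 1.3-fold higher number (0.14 log units; that floor lies within the scatter) from compound 3 to compound 4; the limit leaves it open whether they differ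

Still open, on these data alone, is how either core would answer to a different group at the methoxy place, such as a hydroxyl, an amine or a longer alkoxy chain, since only hydrogen and methoxy appear there. Also open, as far as these compounds go, is what happens when the chlorine shared by all four compounds gives way to an amine or a nitrile.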